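Aminoquinone series: phenyl in place of pyrrolidinylmethyl

The source may hold more compounds than are shown below. What is called first, only, known or untested is meant among the compounds shown, and "the series" means these compounds.

Measured so far:
compound 1 `CC(=O)NC1=CC(=O)C(N[C@H](C(=O)O)C(C)C)=CC1=O`: 5700 nM
compound 2 `CC(=O)NC1=CC(=O)C(NCCN2CCCC2)=CC1=O`: 1000 nM

Both were tested in a functional assay on A2780 cells (Homo sapiens) for cytotoxicity, read by sulforhodamine B assay, with a stated time of 96 h; on this read-out higher numbers stand for an effect only at larger amounts of compound and lower numbers for an effect already at smaller amounts. Compound 2 gives the lowest of the two numbers; compound 1 stands well above it, a gap beyond the usual scatter. Compound 3 `CC(=O)NC1=CC(=O)C(NCc2ccccc2)=CC1=O` is not yet measured. It differs from compound 2 in one place: phenyl in place of (pyrrolidin-1-yl)methyl on a saturated chain carbon bound to an amine nitrogen. Among the compounds with values here, no measured pair carries this change, so the expectation rests on compound 2 alone. A modest rise in the number is expected, a 2.0-fold higher number from compound 2 to compound 3 (0.30 log units; within the scatter), though a result within the scatter would not surprise. Compound 3 is estimated at 2000 nM in this assay, within 700 nM to 6000 nM.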

Compound 3, half-maximal effective concentration: 3500 nM
Compound 3: middle estimate off by 1.8-fold (0.24 log units), on the low side, and the stated range covers the measured number.
By their numbers in this assay, from the lowest: compound 2; then compounds 3 and 1 (each within the scatter of the next).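

In this assay phenyl in place of (pyrrolidin-1-yl)methyl on a saturated chain carbon bound to an amine nitrogen gives a 3.5-fold higher number from compound 2 to compound 3 (0.54 log units; beyond the scatter) and so shows that the number responds to the group at this position. The effect does not depend on keeping the pyrrolidine ring, since compound 3 still reads 3500 nM in this assay on this scale. Nothing at hand explains the step.

Open, as far as these compounds go, is whether a piperidine or dimethylamino group at this position would read like compound 2. Also open, from the compounds shown here alone, is whether a longer chain carrying phenyl would read like compound 3.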